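A few compounds are considered here, and "the series" means these few. Any claim that something is new, unique, unknown or untested is made for them only; others in the source may bear on it.

Working notes on the series. The shared core carries a 2-amino-1,3-thiazol-4-yl group on one six-membered aromatic ring of carbon only and a second such ring joined through a single carbon; compound 1 `Nc1nc(-c2ccc(Cc3cccc(C(F)(F)F)c3)cc2)cs1` bears trifluoromethyl on that second ring, compound 2 `COc1ccc(Cc2ccc(-c3csc(N)n3)cc2)cc1` a different group, and compound 3 `COc1ccc(Cc2ccccc2)cc1` lacks the 2-amino-1,3-thiazol-4-yl group altogether. In an assay on cells for activation of leukotriene A-4 hydrolase (Homo sapiens), with a stated time of 10 min (a higher number here means that more compound is needed for the effect, a lower number that less compound is needed), compound 1 gives 69000 nM, compound 2 gives 210 nM and compound 3 gives 4830 nM. Compound 1 thus gives the highest number of the three; compound 3 stands nearest to it and compound 2 furthest from it. Going by the values given here, the one step within the measured set, a 23-fold higher number from compound 2 to compound 3 (1.36 log units; beyond the scatter), concerns the 2-amino-1,3-thiazol-4-yl group and not the group on the second ring, so it does not bear directly on the change to compound 4 `Cc1cccc(Cc2ccc(-c3csc(N)n3)cc2)c1`, which is methyl in place of trifluoromethyl on an aromatic carbon. Among the compounds with values here, compound 4 keeps the 2-amino-1,3-thiazol-4-yl group that compound 2 also carries, and compound 2 gives a far lower number than compound 1, so a lower number than compound 1 is expected for compound 4 in this assay, although no measured pair shows the methyl for trifluoromethyl exchange itself. Compound 4 is estimated at 1500 nM, within 200 nM to 15000 nM, a step of a 46-fold lower number from compound 1 to compound 4 (1.66 log units; beyond the scatter) expected on that basis.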

Compound 4, concentration for half-maximal activity: 4810 nM
Compound 4: the middle estimate sits 3.2-fold (0.51 log units) below what was measured; the measured number falls inside the stated range.
By their numbers in this assay, from the lowest: compound 2; then compounds 4 and 3 (each within the scatter of the next); then compound 1.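

In this assay, going by these compounds alone, the exchange of trifluoromethyl for methyl on an aromatic carbon, meta to a large group, gives a 14-fold lower number from compound 1 to compound 4 (1.16 log units; beyond the scatter), the first measured change at this position with the 2-amino-1,3-thiazol-4-yl group kept in place. Within the data shown here, the earlier step concerned only that group, so this result adds that the substituent at this position also matters in this assay, even though neither group carries a hydrogen-bond donor, a hydrogen-bond acceptor or a net charge. No measurement at hand explains what in the exchange of these two groups accounts for the step.

The two compounds alone cannot show whether the outcome tracks the loss of the fluorine atoms or the smaller group, nor whether the trend runs beyond this single pair, and a chlorine atom, an amine or a carboxylic acid on the same aromatic carbon would help to separate these readings. Going by these compounds, it also remains open whether the same exchange would give a step of similar size on a core without the 2-amino-1,3-thiazol-4-yl group.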